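From methyl to chloro: compound 2 to compound 4

This account rests on a few compounds, and the source may have more. Where it says the series, first, only, none or still open, it means among the compounds named here.

Measured in a functional assay on HCT-116 cells (Homo sapiens) for antiproliferative activity, read by CCK-8 assay, with a stated time of 72 h; a lower number here means a stronger inhibitor, a higher number a weaker inhibitor:
- compound 1 `Nc1ccccc1NC(=O)c1ccc(CSc2cccc(F)c2)cc1`: 2870 nM
- compound 2 `Cc1ccc(SCc2ccc(C(=O)Nc3ccccc3N)cc2)cc1`: 2630 nM
- compound 3 `Nc1ccccc1NC(=O)/C=C/c1ccc(CSCCc2ccccc2)cc1`: "not determined" (no result reported)

Only two of these compounds have a number, and compound 2 stands level with compound 1: the step is a 1.1-fold lower number from compound 1 to compound 2 (0.04 log units; within the scatter). Compound 4 `Nc1ccccc1NC(=O)c1ccc(CSc2ccc(Cl)cc2)cc1` changes compound 2 in one place: chloro in place of methyl on an aromatic carbon. It carries chloro in place of methyl on an aromatic carbon, para to a large group. For the measured compounds named here, one measured step bears on this, a different swap on the same sulfur-linked ring: a 1.1-fold lower number from compound 1 to compound 2 (0.04 log units; within the scatter). That single step is thin evidence, but it gives no reason to expect a large shift in this assay. The expected step is a 1.1-fold lower number from compound 2 to compound 4 (0.02 log units; within the scatter), which is estimated to stay within the scatter. For compound 4 the estimated value is 2500 nM, with an expected range of 1200 nM to 5000 nM.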

Compound 4, half-maximal inhibitory concentration: 3750 nM
For compound 4 the middle estimate is 1.5-fold (0.18 log units) below the measured one, and the stated range covers the measured number.
By their numbers in this assay, from the lowest: compounds 2, 1 and 4 (each within the scatter of the next).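

In this assay, chloro and methyl on an aromatic carbon, para to a large group, cannot be told apart (a 1.4-fold higher number from compound 2 to compound 4 (0.15 log units; within the scatter)). Putting 4-chlorophenyl in place of 3-fluorophenyl on the sulfur gives the same picture (a 1.3-fold higher number from compound 1 to compound 4 (0.12 log units; within the scatter)), so this is now a second kind of swap on that ring that stays within the usual scatter. Nothing measured here speaks to why these numbers sit so close.

Still open, going by these compounds, is whether a different kind of group on this ring, such as an amine or a carboxylic acid, would give a clearer step. The same question holds for a longer chain on the sulfur in the shared core.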